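From Cyclopropylamine Back to an Arylamine

The source may hold more compounds than are shown below. What is called first, only, known or untested is meant among the compounds shown, and "the series" means these compounds.

The series shares one core, seen in compound 1 `CCc1ccc(NC2=CC(=O)c3c(nc4n3[C@H]3OC[C@@H](O)[C@H]3OC4)C2=O)cc1`, compound 2 `O=C1C(N2CCCC2)=CC(=O)c2c1nc1n2[C@H]2OC[C@@H](O)[C@H]2OC1` and compound 3 `O=C1C(NC2CC2)=CC(=O)c2c1nc1n2[C@H]2OC[C@@H](O)[C@H]2OC1`. In a functional assay on HeLa cells (Homo sapiens) for inhibition, read by sulforhodamine B assay (on this read-out lower numbers stand for stronger inhibition and higher numbers for weaker inhibition), compound 1 gives 6510 nM. Compound 2 reaches only the limit of this assay, > 16000 nM. Compound 3 likewise sits at the limit of this assay, > 16000 nM. Thus compound 3 stands among the two values that rest at the limit of > 16000 nM in this assay, at which 2 of the 3 values shown sit, and nothing more precise is known about it. The step of an at least 2.4-fold higher number from compound 1 to compound 3 (0.39 log units; beyond the scatter) shows that swapping the 4-ethylphenyl for cyclopropyl weakened inhibition, while a step that the two limits leave unreadable from compound 2 to compound 3 is not readable because both sit at the limit.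

Compound 4 `O=C1C(Nc2cccc(Cl)c2)=CC(=O)c2c1nc1n2[C@H]2OC[C@@H](O)[C@H]2OC1` reverses that direction: 3-chlorophenyl in place of cyclopropyl on an amine nitrogen. Since an at least 2.4-fold higher number from compound 1 to compound 3 (0.39 log units; beyond the scatter) marks the loss when an aryl group on the amine nitrogen was replaced by cyclopropyl, returning an aryl group is expected to recover at least that much, so compound 4 is expected to land near compound 1, with the estimated step of an at least 2.2-fold lower number from compound 3 to compound 4 (0.35 log units; beyond the scatter). In this assay compound 4 is therefore estimated at 7000 nM, within a range from 2500 nM to 20000 nM, with some chance that only a limit is reported.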

Compound 4, half-maximal inhibitory concentration: 7970 nM
The estimate for compound 4 lay 1.1-fold (0.06 log units) below the measured number, and the stated range covers the measured number.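

Going by these compounds alone, with 3-chlorophenyl on the amine nitrogen, the step is a 1.2-fold higher number from compound 1 to compound 4 (0.09 log units; within the scatter), so in this assay a second aryl group, carrying a different substituent at a different ring position, cannot be told apart from the 4-ethylphenyl that was the only aryl group on this nitrogen until now. The steps from the two non-aryl amines are an at least 2.0-fold lower number from compound 3 to compound 4 (0.30 log units; that floor lies within the scatter) and an at least 2.0-fold lower number from compound 2 to compound 4 (0.30 log units; that floor lies within the scatter), so on their own they do not establish a real difference from cyclopropylamino or pyrrolidin-1-yl, although the measured number for compound 4 does separate it from both in kind. Those floors are set by compound 2 and compound 3, whose values are limits and not numbers: the limit of > 16000 nM in this assay, at which 2 of the 4 values shown sit.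

From the compounds shown here alone, the true size of both steps therefore stays open, and so does the question of whether the aryl ring alone carries the activity or its substituents contribute, which a plain phenyl would address. Going by these compounds, it is also open how far the aryl group can be changed before activity is lost, for instance with a carboxylic acid on the ring or a benzyl group on the amine nitrogen.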